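The source may report more compounds than this note shows. Statements on the series, on what has been measured and on what is new or still open speak of the compounds shown alone.

Measured in an assay for binding affinity to dual specificity mitogen-activated protein kinase kinase 4 (Homo sapiens), read by KINOMEscan, tested at 100 nM; on this read-out lower numbers stand for a stronger effect and higher numbers for a weaker effect at the one concentration tested:
compound 1 `CCCS(=O)(=O)Nc1ccc(F)c(C(=O)c2n[nH]c3ncc(-c4ccccc4)cc23)c1F`: 2.4%
compound 2 `CCCS(=O)(=O)Nc1ccc(F)c(C(=O)c2n[nH]c3ncc(-c4ccc(F)cc4)cc23)c1F`: 2.1%
compound 3 `CCCS(=O)(=O)Nc1ccc(F)c(C(=O)c2n[nH]c3ncc(-c4cccc(C)c4)cc23)c1F`: 15%

Compound 3 gives the highest, that is the weakest, of these three numbers. Its nearest neighbour is compound 1, as a number 12.6 percentage points higher from compound 1 to compound 3 (beyond the scatter) shows, and compound 2 lies further off, as a number 12.9 percentage points higher from compound 2 to compound 3 (beyond the scatter) shows. Compound 4 `CCCS(=O)(=O)Nc1ccc(F)c(C(=O)c2n[nH]c3ncc(-c4cccc(OC)c4)cc23)c1F` is built from compound 3 by a single change: methoxy in place of methyl on an aromatic carbon. All three measured steps alter the same ring attached to the shared core, so they bear on this change. a number 0.3 percentage points lower from compound 1 to compound 2 (within the scatter) shows that a small group on that ring can leave the number unmoved, while a number 12.6 percentage points higher from compound 1 to compound 3 (beyond the scatter) and a number 12.9 percentage points higher from compound 2 to compound 3 (beyond the scatter) show modest rises. A step of a number 3 percentage points lower from compound 3 to compound 4 (within the scatter) is therefore expected, within the scatter, with the number perhaps drifting back toward the others. Compound 4 is estimated at 12%, with a range from 3% to 30%.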

Compound 4, a percentage reported as activity, at one concentration (the size of the read-out at that concentration, not a potency): 6.3%
The estimate for compound 4 lay 5.7 percentage points above the measured number, and the stated range covers the measured number.
By their numbers in this assay, from the lowest: compounds 2, 1, 4 and 3 (each within the scatter of the next, the first and the last beyond it).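

The 3-methoxyphenyl group gives a number that cannot be separated from any of its three neighbours (a number 8.7 percentage points lower from compound 3 to compound 4 (within the scatter)) (a number 3.9 percentage points higher from compound 1 to compound 4 (within the scatter)) (a number 4.2 percentage points higher from compound 2 to compound 4 (within the scatter)). Methyl in this same place did pass the scatter when it replaced hydrogen (a number 12.6 percentage points higher from compound 1 to compound 3 (beyond the scatter)), whereas methoxy in that place does not, so the two groups differ in how they read against the unsubstituted ring, though not from each other. Nothing available gives a reason for this.

As far as these compounds go, whether an amine or a carboxylic acid in this place would give a number beyond the scatter stays open. So does the effect of methoxy on the other carbons of this ring.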